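The compounds below may be only part of what the source reports. "The series", "measured", "known", "first", "only" and "open" are said of these compounds alone.

Compound 1 `CCCCc1cnc(C(=O)/C=C/c2ccccc2O)cn1` is the starting point of this pair. In a functional assay on the whole organism for inhibition, with Spinacia oleracea as the target, read by spectrophotometry, with a stated time of 4 h (on this read-out lower numbers stand for stronger inhibition and higher numbers for weaker inhibition), compound 1 gives 184000 nM, the lower of the two numbers recorded so far. Its nearest neighbour is compound 2 `CCCCc1cnc(C(=O)/C=C/c2ccc(O)cc2)cn1`, which in this assay gives 306000 nM; the two differ only at the hydroxyphenyl group, and the step of a 1.7-fold higher number from compound 1 to compound 2 (0.22 log units; within the scatter) lies within the scatter, so neither compound can be called the stronger inhibitor.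

Compound 3 `CCCc1cnc(C(=O)/C=C/c2ccccc2O)cn1` differs from compound 1 in the chain on the core: hydrogen in place of methyl on a saturated chain carbon, three bonds along the chain from an aromatic carbon. Among the compounds with values here, no measured step touches this chain, and the single measured step, which concerns the hydroxyphenyl group, stayed within the scatter. On that basis compound 3 is expected to sit close to compound 1 in this assay, with no step beyond the scatter; the expected step is a 1.1-fold higher number from compound 1 to compound 3 (0.04 log units; within the scatter). The estimate for compound 3 is therefore 200000 nM, between 80000 nM and 500000 nM.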

Compound 3, half-maximal inhibitory concentration: 187000 nM
The estimate for compound 3 lay 1.1-fold (0.03 log units) above the measured number, within the range that was stated.
By their numbers in this assay, from the lowest: compounds 1, 3 and 2 (each within the scatter of the next).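

Within the data shown here, the difference of butyl to propyl is the first measured step at the chain on the core, and in this assay it reads a 1.0-fold higher number from compound 1 to compound 3 (0.01 log units; within the scatter) and leaves the two compounds indistinguishable. The earlier pair showed this only for the hydroxyphenyl group, so both places varied so far have now given steps within the scatter, and for these two chains the assay gives no sign that this position matters. Nothing measured here offers an explanation for this result.

With only butyl and propyl shown, it remains open whether a longer chain such as octyl, or a much shorter one such as methyl, would give a step beyond the scatter. Going by these compounds, it also remains open whether an amine or a carboxylic acid at the end of the chain would do so.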